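Swapping the Amine Substituent on a Shared Kinase-Inhibitor Core

The compounds below may be only part of what the source reports. "The series", "measured", "known", "first", "only" and "open" are said of these compounds alone.

Measured compounds:
compound 1, `CC1(N)CCN(c2ncnc3[nH]cc(-c4cccc(Cl)c4)c23)CC1`: 163 nM
compound 2, `CN(C)c1ncnc2[nH]cc(-c3cccc(Cl)c3)c12`: 81 nM

Both compounds were tested in an assay for inhibition of serine/threonine-protein kinase 4 (Homo sapiens), read by luminescence and ADP-Glo, in the presence of a further agent that is not named here; on this read-out higher numbers stand for weaker inhibition and lower numbers for stronger inhibition. Of the two numbers, compound 2 holds the one that is smaller, yet the step of a 2.0-fold lower number from compound 1 to compound 2 (0.30 log units; within the scatter) falls within the scatter of this assay, so the two compounds cannot be told apart on these data. That step exchanged one amine group for another on the same aromatic carbon of the shared core.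

Compound 3, `Clc1cccc(-c2c[nH]c3ncnc(NCC4CC4)c23)c1`, has not been measured. It differs from compound 2 in one place: (cyclopropylmethyl)amino in place of dimethylamino on an aromatic carbon. For the measured compounds named here, the only measured step that bears on this is again an exchange of the amine on that carbon, and it moved the number by no more than the scatter allows. Going by the values given here, there is no measured example of a secondary amine or of a three-membered ring in this place, so the expectation rests on that single step alone. Compound 3 is therefore expected to land near compound 2, with a step of a 1.2-fold higher number from compound 2 to compound 3 (0.09 log units; within the scatter) that stays within the scatter. The estimate for compound 3 is 100 nM, with a range from 35 nM to 300 nM.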

Compound 3, half-maximal inhibitory concentration: 140 nM
Beside the measured number, compound 3's estimate is 1.4-fold (0.15 log units) below it, and the stated range covers the measured number.
By their numbers in this assay, from the lowest: compounds 2, 3 and 1 (each within the scatter of the next).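

Compound 3 places a secondary amine and a three-membered ring at this aromatic carbon, features that neither earlier compound has there, and replacing dimethylamino with (cyclopropylmethyl)amino gives a 1.7-fold higher number from compound 2 to compound 3 (0.24 log units; within the scatter). Replacing 4-amino-4-methylpiperidin-1-yl with the same group gives a 1.2-fold lower number from compound 1 to compound 3 (0.07 log units; within the scatter), so in this assay these three amine groups cannot be told apart, even though they differ clearly in shape and in the substitution of the attached nitrogen. No evidence is available that bears on this result.

From the compounds shown here alone, all three groups join the shared core through a nitrogen, so it remains open what a methoxy group or a plain hydrogen on this carbon would do to the number. Going by these compounds, it also remains open whether the three-membered ring matters in itself, a question that an open chain such as propylamino could help to answer.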